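The source may report more compounds than this note shows. Statements on the series, on what has been measured and on what is new or still open speak of the compounds shown alone.

Of the compounds shown here, three have been measured in a physicochemical assay for lipophilicity, read by HPLC; a higher number here means a more lipophilic compound, a lower number a more polar compound. Compound 1 `O=C1/C(=C\c2ccncc2)C(c2ccccc2)Oc2ccccc21` gives 2.85, and compound 2 `O=C1/C(=C/c2ccc(Br)cc2)C(c2ccccc2)Oc2ccccc21` gives 4.46. Compound 3 `O=c1c(Cc2ccc([N+](=O)[O-])cc2)coc2ccccc12`, with a core of its own, gives 3.93. That places compound 3 second of the three, under compound 2 and over compound 1, and both gaps lie beyond the scatter.

Compound 4 `N#Cc1ccc(Cc2coc3ccccc3c2=O)cc1` departs from compound 3 in a single place: cyano in place of nitro on an aromatic carbon. The rest of the structure stays the same.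

Going by the values given here, no two measured compounds differ in one place only, so the data offer no direct measure of this exchange. The expectation therefore starts from compound 3 at 3.93 and rests on the structural change alone. A small downward move in this assay is expected, one that may not clear the scatter. The estimated change is a number 0.28 log units lower from compound 3 to compound 4 (within the scatter). This is a modest expectation, and a result level with the starting value would not contradict it. For compound 4 the expected value is 3.65, with an estimated range from 3.3 to 4.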

Compound 4, partition coefficient: 3.58
For compound 4 the middle estimate is 0.07 log units above the measured one; the range from low to high includes it.
By their numbers in this assay, from the lowest: compound 1; then compound 4; then compound 3; then compound 2.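

In this assay, the exchange of nitro for cyano on an aromatic carbon, para to a large group, gives the first direct measure of a change in one place among these compounds: the number reads a number 0.35 log units lower from compound 3 to compound 4 (beyond the scatter). Going by these compounds alone, compounds 1, 2 and 3 offered no such pair, so until now this position had no measured step at all, and it now has one that clears the scatter, though only modestly. The data give no measured basis for explaining the step, so it stands here as an observation alone, with nitro and cyano known only by their names and the atoms counted for each.

The compounds shown leave open how an amine, a carboxylic acid or a methoxy group would read at this same place on the ring of carbon only, since a single exchange fixes no trend across groups. They also leave open whether nitro and cyano would differ by a similar amount on the core of compound 1, where neither group appears.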